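A few compounds are considered here, and "the series" means these few. Any claim that something is new, unique, unknown or untested is made for them only; others in the source may bear on it.

In an assay on isolated protein for agonist activity at Bile acid receptor (Homo sapiens), read by TR-FRET (on this read-out higher numbers stand for an effect only at larger amounts of compound and lower numbers for an effect already at smaller amounts), compound 3 `CC(C)c1onc(-c2c(Cl)cccc2Cl)c1COc1ccc(-c2nc3ccc(C(=O)O)cc3n2-c2ccc(F)cc2)cc1` gives 15.1 nM. Compound 2 `CCCC(CCC)n1c(-c2ccc(OCc3c(-c4c(Cl)cccc4Cl)noc3C(C)C)cc2)nc2ccc(C(=O)O)cc21` gives 30.3 nM in this assay, and the change a 2.0-fold lower number from compound 2 to compound 3 (0.30 log units; within the scatter) stays within the scatter. Compound 1 `CC(C)c1onc(-c2c(Cl)cccc2Cl)c1COc1ccc(-c2nc3ccc(C(=O)O)cc3n2CC2CCCCC2)c(F)c1` gives "not determined" (no result reported) in this assay, so no number is available for it. Compound 4 `CC(C)c1onc(-c2c(Cl)cccc2Cl)c1COc1ccc(-c2nc3ccc(C(=O)O)cc3n2CC2CCCCC2)cc1` differs from compound 3 by cyclohexylmethyl in place of 4-fluorophenyl on an aromatic nitrogen. Among the measured compounds shown here, the only measured step at this aromatic nitrogen, the swap of a branched chain for the aryl group between compound 2 and compound 3, was small, so no move beyond the scatter is expected here either. The number for compound 4 is estimated at 22 nM, with a range from 8 nM to 60 nM. That expectation amounts to a step of a 1.5-fold higher number from compound 3 to compound 4 (0.16 log units; within the scatter).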

Compound 4, half-maximal effective concentration: 19.9 nM
The estimate for compound 4 lay 1.1-fold (0.04 log units) above the measured number, within the range that was stated.
By their numbers in this assay, from the lowest: compounds 3, 4 and 2 (each within the scatter of the next).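

In this assay, replacing 4-fluorophenyl with cyclohexylmethyl on the aromatic nitrogen gives a 1.3-fold higher number from compound 3 to compound 4 (0.12 log units; within the scatter), and replacing 1-propylbutyl with it gives a 1.5-fold lower number from compound 2 to compound 4 (0.18 log units; within the scatter). A non-aromatic ring thus joins an aromatic ring and a branched chain at this position, and the assay does not separate the three groups in compounds 2, 3 and 4. Nothing available explains this absence of separation. From the compounds shown here alone, it remains open whether the picture holds for a group carrying an amine or a hydroxyl, or for a methyl on this nitrogen.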